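Propyl to tert-Butyl at the Ester Oxygen

The source may hold more compounds than are shown below. What is called first, only, known or untested is meant among the compounds shown, and "the series" means these compounds.

In this series compound 3 `CCCOC(=O)C1=C(C)NC(=S)NC1c1cccs1` gives 10% in an assay on membranes from HeLa cells for displacement of a labelled ligand from adenosine receptor A3 (Homo sapiens), read by scintillation counting, with a stated time of 180 min, tested at 1 uM (a higher number here means more inhibition at the concentration tested (going by the name of the read-out), a lower number less inhibition), the highest of the three numbers at hand, though compound 1 `CC1=C(C(=O)OC(C)(C)C)C(c2ccco2)NC(=S)N1` at 9% and compound 2 `COC(=O)C1=C(C)NC(=S)NC1c1cccs1` at 1% both lie within the scatter of it. Going by the values given here, the only single-point step seen so far, a number 9 percentage points higher from compound 2 to compound 3 (within the scatter), came from ethyl in place of hydrogen on a saturated chain carbon bound to an oxygen next to a carbonyl group and stayed within the scatter. Compound 4 `CC1=C(C(=O)OC(C)(C)C)C(c2cccs2)NC(=S)N1` differs from compound 3 by tert-butyl in place of propyl on an oxygen next to a carbonyl group. Compound 1, which also carries a tert-butyl group on that oxygen, gives 9%. Among the compounds with values here, with every number so far low, compound 4 is expected to move little, an estimated step of a number 2 percentage points lower from compound 3 to compound 4 (within the scatter) giving 8%, within a range from 0% to 20%.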

Compound 4, a percentage reported as inhibition, at one concentration (the size of the read-out at that concentration, not a potency): 22%
The estimate for compound 4 lay 14 percentage points below the measured number, and the stated range ends below it.
By their numbers in this assay, from the lowest: compounds 2, 1 and 3 (each within the scatter of the next); then compound 4.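

On an oxygen next to a carbonyl group, tert-butyl now gives steps beyond the scatter in this assay: against propyl, a number 12 percentage points higher from compound 3 to compound 4 (beyond the scatter), and against methyl, a number 21 percentage points higher from compound 2 to compound 4 (beyond the scatter). The ring group also counts, since thiophen-2-yl in place of furan-2-yl on a saturated ring carbon, with tert-butyl kept, gives a number 13 percentage points higher from compound 1 to compound 4 (beyond the scatter). No measurement at hand explains either change. Still open, as far as these compounds go, is how a benzyl or cyclopropyl group on that oxygen would read, and whether the tert-butyl step holds with furan-2-yl on the ring carbon.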